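Swapping the ring-nitrogen aryl for a sulfonyl group

A few compounds are considered here, and "the series" means these few. Any claim that something is new, unique, unknown or untested is made for them only; others in the source may bear on it.

Working notes on the series. Three compounds have been run in a functional assay on the whole organism (strain Kunming) for inhibition, with Mus musculus as the target, with a stated time of 1 h, at a dose of 40 mg/kg by the oral route; on this read-out lower numbers stand for less inhibition and higher numbers for more inhibition at the one dose given (going by the name of the read-out). Compound 1 `O=C(/C=C/c1ccccc1)c1ccc(N2CCN(c3ccc(Cl)c(Cl)c3)CC2)cc1` gives 13.4%. Compound 2 `COc1cccc(N2CCN(c3ccc(C(=O)/C=C/c4ccccc4)cc3)CC2)c1` gives 16%. Compound 3 `O=C(/C=C/c1ccccc1)c1ccc(N2CCN(c3ccccc3)CC2)cc1` gives 3.71%. The step of a number 2.6 percentage points higher from compound 1 to compound 2 (within the scatter) and the step of a number 9.7 percentage points lower from compound 1 to compound 3 (within the scatter) both stay within the usual scatter, while the step of a number 12.3 percentage points lower from compound 2 to compound 3 (beyond the scatter) is a modest one beyond it. On the numbers shown, compound 3 sits at the lowest of the three: its gap to compound 1 is within the scatter, its gap to compound 2 beyond it.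

Compound 4 `Cc1ccc(S(=O)(=O)N2CCN(c3ccc(C(=O)/C=C/c4ccccc4)cc3)CC2)cc1` is not yet measured. The change from compound 3 is (4-methylphenyl)sulfonyl in place of phenyl on an amine nitrogen in a ring. Among the compounds with values here, the steps that bear on it are those at the same amine nitrogen, from compound 1 to compound 3 and from compound 2 to compound 3, both of them small to modest in size, and none of them brings in a sulfonyl, so the new group has no measured precedent here. The step of a number 8.3 percentage points higher from compound 3 to compound 4 (within the scatter) is therefore expected to stay small, most likely within the scatter. For compound 4 the estimate in this assay is 12%, with a range from 0% to 30%.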

Compound 4, a percentage reported as inhibition, in the whole organism at one dose (the size of the read-out at that dose, not a potency): 30.8%
For compound 4 the middle estimate is 18.8 percentage points below the measured one; measured number above the stated range.
By their numbers in this assay, from the lowest: compounds 3, 1 and 2 (each within the scatter of the next, the first and the last beyond it); then compound 4.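

In this assay the amine nitrogen in the ring can carry a sulfonyl-linked group as well as a directly attached aryl ring, and (4-methylphenyl)sulfonyl gives a number 27.1 percentage points higher from compound 3 to compound 4 (beyond the scatter) against phenyl, a number 14.8 percentage points higher from compound 2 to compound 4 (beyond the scatter) against 3-methoxyphenyl and a number 17.4 percentage points higher from compound 1 to compound 4 (beyond the scatter) against 3,4-dichlorophenyl. Within the data shown here, all three steps lie beyond the scatter, so compound 4 stands highest of the four, whereas among the aryl groups only the step between compound 2 and compound 3 left the scatter. Nothing at hand explains the gain, and no measurement bears on why this group reads higher.

The compounds shown do not separate the contribution of the sulfonyl link from that of the 4-methylphenyl ring it carries, and a methylsulfonyl group, an unsubstituted phenylsulfonyl group or a benzoyl group at the same nitrogen would begin to pull these apart. With a single dose and a single time point, the read-out also leaves open whether the higher number for compound 4 would hold at other doses.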